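Compound 3: A Bromo Added to Compound 1

The source may report more compounds than this note shows. Statements on the series, on what has been measured and on what is new or still open speak of the compounds shown alone.

In a functional assay on HCT-116 cells (Homo sapiens) for cytotoxicity, read by sulforhodamine B assay, with a stated time of 48 h (a higher number here means a weaker inhibitor, a lower number a stronger inhibitor), compound 1 `Cc1cc2ncc(S(=O)(=O)c3ccccc3)c(-c3ccccc3)n2n1` gives > 25 ug/mL, which is a limit of the assay and not a number. Compound 2 `O=S(=O)(c1ccccc1)c1cnc2cc(-c3ccc(Cl)cc3)nn2c1-c1ccccc1`, carrying 4-chlorophenyl in place of methyl on an aromatic carbon, gives 1.64 ug/mL. Within the data shown here, this is the only measured step, an at least 15-fold lower number from compound 1 to compound 2 (1.18 log units; beyond the scatter), and it is large and beyond the scatter. Compound 3 `Cc1nn2c(-c3ccccc3)c(S(=O)(=O)c3ccccc3)cnc2c1Br` keeps the methyl of compound 1 and has bromo in place of hydrogen on an aromatic carbon. The measured step bears on this change only loosely, since it replaces the methyl and brings in a ring, whereas the bromo brings no ring. A much smaller step in the same direction is therefore expected, and compound 3 may still reach the limit. The expected step is an at least 1.2-fold lower number from compound 1 to compound 3 (0.09 log units; that floor lies within the scatter). For compound 3, the estimated value is 20 ug/mL, with an expected range of 7 ug/mL to 45 ug/mL.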

Compound 3, half-maximal inhibitory concentration: 2.21 ug/mL
The estimate for compound 3 lay 9.0-fold (0.96 log units) above the measured number; the measured number lies below the stated range.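

In this assay, among these compounds, the earlier compounds showed a change only at the aromatic carbon that bears the methyl group. Compound 3 shows that the neighbouring aromatic carbon of the five-membered aromatic ring also responds, with an at least 11-fold lower number from compound 1 to compound 3 (1.05 log units; beyond the scatter), and that a large step there needs only 1 heavy atom and no ring. Compound 1 gives > 25 ug/mL, which is a limit of the assay and not a number, so this step is a floor: the limit of > 25 ug/mL in this assay, at which 1 of the 3 values shown sits.

As far as these compounds go, what an amine or a carboxylic acid would do on this carbon in place of bromo stays open, so it cannot be said whether the step belongs to bromo in particular. Also open, from the compounds shown here alone, is how bromo and 4-chlorophenyl would act together on the shared core.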